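Compound 3 gains a five-membered aromatic ring

This account rests on a few compounds, and the source may have more. Where it says the series, first, only, none or still open, it means among the compounds named here.

Of the compounds shown here, three sharing one core have been tested in a functional assay on HCT-116 cells (Homo sapiens) for inhibition, read by sulforhodamine B assay, with a stated time of 2 days; on this read-out lower numbers stand for stronger inhibition of growth and higher numbers for weaker inhibition of growth: compound 1 `CC1=C(C(=O)Nc2cccc([N+](=O)[O-])c2)C(c2ccc(O)cc2O)NC(SCc2ccccc2)=N1`, compound 2 `CC1=C(C(=O)Nc2cccc([N+](=O)[O-])c2)C(c2ccc(O)cc2O)NC(NCc2ccccc2)=N1` and compound 3 `CC1=C(C(=O)Nc2cccc([N+](=O)[O-])c2)C(c2ccc(O)cc2O)NC(NN)=N1`. They differ only in the group on the carbon with a double bond to nitrogen. Compound 1, with benzylsulfanyl there, gives 29000 nM. Compound 3, with aminoamino there, gives 47700 nM. The two stand within the scatter of each other, as a 1.6-fold higher number from compound 1 to compound 3 (0.22 log units; within the scatter) shows. Compound 2, with benzylamino, is recorded only as a limit, > 100000 nM. The remaining steps are an at least 3.4-fold higher number from compound 1 to compound 2 (0.53 log units; beyond the scatter) and an at least 2.0-fold lower number from compound 2 to compound 3 (0.32 log units; beyond the scatter).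

Compound 4 `CC1=C(C(=O)Nc2cccc([N+](=O)[O-])c2)C(c2ccc(O)cc2O)NC(N/N=C/c2cccs2)=N1` keeps the core of compound 3 and changes it on an amine nitrogen: a group of 7 heavy atoms (5 carbon, 1 nitrogen, 1 sulfur; one five-membered aromatic ring with 1 hetero atom) in place of one nitrogen atom, on an amine nitrogen. The amino leaves, and the entering group brings one five-membered aromatic ring. The measured steps at this place give no single direction for a ring-bearing group. Compound 1 differs from compound 3 by a 1.6-fold higher number from compound 1 to compound 3 (0.22 log units; within the scatter), within the scatter, whereas compound 2 differs from it by an at least 2.0-fold lower number from compound 2 to compound 3 (0.32 log units; beyond the scatter). No step beyond the scatter is therefore expected in this assay, the expected step being a 1.4-fold lower number from compound 3 to compound 4 (0.13 log units; within the scatter). Compound 4 is estimated at 35000 nM, with an expected range from 10000 nM to 100000 nM.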

Compound 4, concentration for 50% growth inhibition: 38200 nM
Compound 4: middle estimate off by 1.1-fold (0.04 log units), on the low side; low and high end bracket the measured number.
By their numbers in this assay, from the lowest: compounds 1, 4 and 3 (each within the scatter of the next). At a limit, above all of these: compound 2.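

In this assay, the group bearing one five-membered aromatic ring takes the place of amino on the amine nitrogen with no step beyond the scatter, a 1.2-fold lower number from compound 3 to compound 4 (0.10 log units; within the scatter), and it also stays within the scatter of the benzylsulfanyl of compound 1, a 1.3-fold higher number from compound 1 to compound 4 (0.12 log units; within the scatter), so compounds 1, 3 and 4 now form one level that a larger ring-bearing group can share. A ring-bearing group on this amine nitrogen therefore does not by itself go with the weak end of this small series: the benzyl of compound 2 and the new group differ clearly, an at least 2.6-fold lower number from compound 2 to compound 4 (0.41 log units; beyond the scatter). That step has only one firm end, as the entry for compound 2 is a limit and not a number: the limit of > 100000 nM in this assay, at which 1 of the 4 values shown sits.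

The compounds shown leave open whether the difference from compound 2 lies with the five-membered aromatic ring or with the double bond outside aromatic rings in the entering group. A phenyl ring or a furan ring on the same chain would separate these two, and an amine or a carboxylic acid on the five-membered ring would show whether this level in this assay can move at all.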